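A few compounds are considered here, and "the series" means these few. Any claim that something is new, unique, unknown or untested is made for them only; others in the source may bear on it.

Compound 2 `CC(Nc1nnc2nncn2n1)C(=O)O` and compound 1 `OCCNc1nnc2nncn2n1` share a core and differ only in the group on a nitrogen on an aromatic ring. In a functional assay on HL-60 cells (Homo sapiens) for inhibition, read by MTT assay, with a stated time of 72 h (on this read-out higher numbers stand for weaker inhibition and lower numbers for stronger inhibition), compound 1 gives 45300 nM, and compound 2 gives 74300 nM, so the two sit together within the scatter, as the step of a 1.6-fold higher number from compound 1 to compound 2 (0.21 log units; within the scatter) shows. Compound 3 `OCC(CO)(CO)Nc1nnc2nncn2n1` carries a larger group at the same place; in this assay compound 3 reaches only a limit, > 100000 nM (the limit of > 100000 nM in this assay, at which 1 of the 3 values shown sits). Compound 4 `CCCCNc1nnc2nncn2n1` is the next change: butyl in place of 1-carboxyethyl on a nitrogen on an aromatic ring. Within the data shown here, the only measured step at this position, a 1.6-fold higher number from compound 1 to compound 2 (0.21 log units; within the scatter), stayed within the scatter, so no step beyond the scatter is expected in this assay. For compound 4 the estimate is 50000 nM, between 15000 nM and 100000 nM, which means an expected step of a 1.5-fold lower number from compound 2 to compound 4 (0.17 log units; within the scatter).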

Compound 4, half-maximal inhibitory concentration: 36200 nM
For compound 4 the middle estimate is 1.4-fold (0.14 log units) above the measured one; measured number inside the range.
By their numbers in this assay, from the lowest: compounds 4, 1 and 2 (each within the scatter of the next, the first and the last beyond it). At a limit, above all of these: compound 3.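

Butyl in place of 1-carboxyethyl on this nitrogen gives the first measured step here that passes the scatter, though only modestly (a 2.1-fold lower number from compound 2 to compound 4 (0.31 log units; beyond the scatter)). Ethyl in place of hydroxy on a saturated chain carbon, in contrast, stays within the scatter (a 1.3-fold lower number from compound 1 to compound 4 (0.10 log units; within the scatter)). Nothing shown here explains either step. The compounds shown leave open how an amine, a longer chain such as octyl, or a phenyl ring on this nitrogen would read in this assay.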